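The compounds below may be only part of what the source reports. "The series", "measured", "known", "first", "only" and "open" are said of these compounds alone.

In a functional assay on HL-60 cells (Homo sapiens) for cytotoxicity, read by WST assay, with a stated time of 48 h (on this read-out lower numbers stand for an effect already at smaller amounts and higher numbers for an effect only at larger amounts of compound), three compounds built on one shared core have been measured so far. Compound 1 `Oc1ccccc1C[C@H]1COC[C@@H]1Cc1ccc(Cl)c(Cl)c1` gives 34000 nM, compound 2 `Oc1ccc(C[C@H]2COC[C@@H]2Cc2ccc(Cl)c(Cl)c2)cc1` gives 31000 nM, and compound 3 `CCCCc1ccc(C[C@H]2COC[C@@H]2Cc2ccc(Cl)c(Cl)c2)cc1` gives 23000 nM. Compound 3 thus stands level with the other two, since all three numbers lie within the usual scatter of one another. The next compound, compound 4 `Fc1ccc(C[C@H]2COC[C@@H]2Cc2ccc(Cl)c(Cl)c2)cc1`, has fluoro in place of butyl on an aromatic carbon, para to a large group (fluoro in place of butyl on an aromatic carbon). For the measured compounds named here, two measured steps bear on this change. With 4-hydroxyphenyl in place of 2-hydroxyphenyl, the data show a 1.1-fold lower number from compound 1 to compound 2 (0.04 log units; within the scatter). More directly, butyl in place of hydroxy on an aromatic carbon gave a 1.3-fold lower number from compound 2 to compound 3 (0.13 log units; within the scatter). Neither step goes beyond the scatter, so no step beyond the scatter is expected in this assay, in either direction. The expected step is a 1.3-fold higher number from compound 3 to compound 4 (0.12 log units; within the scatter). For compound 4 the estimated value is 30000 nM, with an expected range from 15000 nM to 55000 nM.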

Compound 4, half-maximal effective concentration: 43000 nM
For compound 4 the middle estimate is 1.4-fold (0.16 log units) below the measured one; low and high end bracket the measured number.
By their numbers in this assay, from the lowest: compounds 3, 2, 1 and 4 (each within the scatter of the next).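

In this assay, the aromatic carbon para to a large group accepts fluoro as well as butyl or hydroxy without a step beyond the scatter: fluoro in place of butyl gives a 1.9-fold higher number from compound 3 to compound 4 (0.27 log units; within the scatter), and fluoro in place of hydroxy gives a 1.4-fold higher number from compound 2 to compound 4 (0.14 log units; within the scatter). Moving to 4-fluorophenyl from 2-hydroxyphenyl likewise gives a 1.3-fold higher number from compound 1 to compound 4 (0.10 log units; within the scatter), so the new compound extends the set of substituents at this place, and still no change among these compounds separates from the rest. No measurement is available that would explain this flat picture.

As far as these compounds go, whether an amine or a carboxylic acid on this aromatic carbon would produce a step beyond the scatter remains open. So does the effect of changing the other parts of the shared core, which stay the same in all these compounds.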